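The source may hold more compounds than are shown below. What is called first, only, known or untested is meant among the compounds shown, and "the series" means these compounds.

Measured compounds:
compound 1, `COc1cc(-c2nc(C(c3ccc(F)cc3)c3ccc(F)cc3)sc2CC(=O)O)ccn1`: 380 nM
compound 2, `COc1ccc(C(c2ccccc2)c2nc(-c3ccc(Cl)cc3)c(CC(=O)O)s2)cc1`: 76 nM

Both numbers come from an in vitro functional assay on HEK285-7 cells for antagonist activity at prostaglandin D2 receptor 2 (Homo sapiens), read by BRET and beta-arrestin recruitment; a higher number here means a weaker inhibitor, a lower number a stronger inhibitor. Compound 1 stands at the higher of the two values; compound 2 sits at a lower value, and the gap between them lies beyond the scatter. Among the compounds with values here, no measured pair here differs in one place only, so no single structural change is isolated by the data.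

Compound 3, `CN(C)c1cc(-c2nc(C(c3ccc(F)cc3)c3ccc(F)cc3)sc2CC(=O)O)ccn1`, is not yet measured. It differs from compound 1 in one place: dimethylamino in place of methoxy on an aromatic carbon. Nothing measured shows what this exchange does on the shared core, and the comparison of compound 1 with compound 2 mixes several changes at once, so it gives no guidance. The step of a 1.1-fold lower number from compound 1 to compound 3 (0.04 log units; within the scatter) is therefore expected to be small, in either direction, and not beyond the scatter. For compound 3 the estimate in this assay is 350 nM, with a range from 150 nM to 900 nM.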

Compound 3, half-maximal inhibitory concentration: > 100000 nM
Compound 3 ended at the assay's limit (the forecaster's own chance of this, stated with the estimate: 3%); middle value at least 280-fold (2.45 log units) away from the limit.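

In this assay, the exchange of methoxy for dimethylamino next to the ring nitrogen gives an at least 260-fold higher number from compound 1 to compound 3 (2.42 log units; beyond the scatter). The value of compound 3 is a limit of the assay and not a number: the limit of > 100000 nM in this assay, at which 1 of the 3 values shown sits.

This position is therefore far from indifferent to the group it carries: one replacement on the shared core, with one hydrogen-bond acceptor on each side and no net charge on either, takes the series from a measurable value in this assay to the limit.

The compounds shown do not separate the effect of the nitrogen from that of the extra carbon; an amino, methylamino or ethoxy group at this carbon would bear on that question. As far as these compounds go, whether the exchange has the same outcome on any other core remains open.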